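The compounds below may be only part of what the source reports. "The series", "measured", "known", "first", "only" and "open" are said of these compounds alone.

Measured compounds:
compound 1, `CCC1=C(O)c2c(oc(-c3ccc(CC(C)C)cc3)cc2=O)C(CC)(CC)C1=O`, 29.3 uM
compound 2, `CCCOc1ccc(-c2cc(=O)c3c(o2)C(CC)(CC)C(=O)C(CC)=C3O)cc1`, > 50.5 uM
compound 3, `CCC1=C(O)c2c(oc(-c3ccc(CBr)cc3)cc2=O)C(CC)(CC)C1=O`, > 46.5 uM

In a functional assay on KB cells (Homo sapiens) for antiproliferative activity, read by sulforhodamine B assay, with a stated time of 3 days (on this read-out higher numbers stand for an effect only at larger amounts of compound and lower numbers for an effect already at smaller amounts), compound 1 gives 29.3 uM. For compound 2 the result is a limit of the assay, > 50.5 uM. For compound 3 the result is likewise a limit of the assay, > 46.5 uM, so compound 3 stands at the upper edge of what this assay reports, together with one further value that is also a limit (the limit of > 46.5 uM in this assay, at which 1 of the 3 values shown sits).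

The unmeasured compound 4, `CCC1=C(O)c2c(oc(-c3ccc(OC)c(F)c3)cc2=O)C(CC)(CC)C1=O`, differs from compound 3 by 3-fluoro-4-methoxyphenyl in place of 4-(bromomethyl)phenyl on an aromatic carbon. Within the data shown here, two measured steps bear on changes at the same aromatic carbon: an at least 1.7-fold higher number from compound 1 to compound 2 (0.23 log units; that floor lies within the scatter) and an at least 1.5-fold higher number from compound 1 to compound 3 (0.20 log units; that floor lies within the scatter). Both floors lie within the scatter, and the step that the two limits leave unreadable from compound 2 to compound 3 gives no readable size. Nothing among these shows that a change on this ring lowers the number beyond the scatter. Compound 4 is therefore expected to stay near the limit, with an estimated 45 uM (range 20 uM to 100 uM). The expected step of an at least 1.0-fold lower number from compound 3 to compound 4 (0.01 log units; that floor lies within the scatter) is within the scatter.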

Compound 4, concentration for half-maximal effect: 26.7 uM
The estimate for compound 4 lay 1.7-fold (0.23 log units) above the measured number; the measured number falls inside the stated range.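

In this assay compound 4 gives 26.7 uM and compound 1 gives 29.3 uM, so two different phenyl groups on this aromatic carbon, next to the ring oxygen, now give readable numbers. The result for compound 3 is a limit of the assay: the limit of > 46.5 uM in this assay, at which 1 of the 4 values shown sits. Placing 3-fluoro-4-methoxyphenyl here in place of 4-(bromomethyl)phenyl gives an at least 1.7-fold lower number from compound 3 to compound 4 (0.24 log units; that floor lies within the scatter), so the change has a lower bound on its size but is not shown to go beyond the scatter.

The compounds shown do not separate the fluoro group from the methoxy group in compound 4, and none brings the number down beyond the scatter. On these data alone, whether an amine or a carboxylic acid on this phenyl ring, or a longer chain in place of the methoxy group, would do so stays open.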